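Phenol for Methoxy on the Fused Core

This account rests on a few compounds, and the source may have more. Where it says the series, first, only, none or still open, it means among the compounds named here.

Compound 1, `Cc1cc(-c2cccc(F)c2)c2ncc(CSCCc3ccccc3)n2c1`: 20 ug/mL
Compound 2, `Cc1cc(I)c2ncc(CSCCc3ccccc3)n2c1`: >= 4 ug/mL
Compound 3, `COc1ccc(-c2cc(C)cn3c(CSCCc4ccccc4)cnc23)cc1`: 20 ug/mL

In an ADME assay on HEL cells (Homo sapiens) for cytotoxicity, with a stated time of 3 days (a lower number here means that less compound is tolerated, a higher number that more compound is tolerated), compound 1 gives 20 ug/mL and compound 3 gives 20 ug/mL, so compound 3 stands level with compound 1 at the digits shown. The value of compound 2 in this assay is a limit of the assay, >= 4 ug/mL; (the limit of >= 4 ug/mL in this assay, at which 1 of the 3 values shown sits). Of the three steps, only no change at the digits printed from compound 1 to compound 3 (within the scatter) is readable, while a step that the limit leaves unreadable from compound 1 to compound 2 and a step that the limit leaves unreadable from compound 2 to compound 3 are left unreadable by that limit.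

Compound 4, `Cc1cc(-c2cccc(O)c2)c2ncc(CSCCc3ccccc3)n2c1`, differs from compound 3 in one place: 3-hydroxyphenyl in place of 4-methoxyphenyl on an aromatic carbon. Within the data shown here, the only readable step, no change at the digits printed from compound 1 to compound 3 (within the scatter), exchanged one substituted phenyl for another on the same aromatic carbon and stayed within the scatter; the change to compound 4 is again an exchange between substituted phenyls at that carbon. On that basis the step to compound 4 is expected to be no change at the digits printed from compound 3 to compound 4 (within the scatter), nothing beyond the scatter. Compound 4 is therefore estimated at 20 ug/mL, in the range from 8 ug/mL to 50 ug/mL.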

Compound 4, minimum cytotoxic concentration: 20 ug/mL
The estimate for compound 4 equals the measured number at the digits printed, within the range that was stated.
By their numbers in this assay, from the lowest: compounds 1, 3 and 4 (each within the scatter of the next).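

At this aromatic carbon, ortho to a fused ring, 3-hydroxyphenyl in place of 4-methoxyphenyl brings in a hydrogen-bond donor, and this assay shows no change at the digits printed from compound 3 to compound 4 (within the scatter). Hydroxy in place of fluoro on the same phenyl position shows no change at the digits printed from compound 1 to compound 4 (within the scatter), so the earlier readable result for an exchange between substituted phenyls now also holds for a phenyl carrying a hydrogen-bond donor. The step from compound 2 to compound 4 cannot be read because the value of compound 2 is a limit: the limit of >= 4 ug/mL in this assay, at which 1 of the 4 values shown sits.

The compounds shown leave open whether an amine or a carboxylic acid on this phenyl, or a longer chain at this carbon, would give a step beyond the scatter. They also leave open how 4-hydroxyphenyl would compare with 3-hydroxyphenyl here.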